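A few compounds are considered here, and "the series" means these few. Any claim that something is new, unique, unknown or untested is made for them only; others in the source may bear on it.

Of the compounds shown here, three of the shared core have been measured in an assay on L cells for inhibition of Protein-serine O-palmitoleoyltransferase porcupine (Mus musculus), read by reporter gene assay, with a stated time of 24 h; on this read-out higher numbers stand for an effect only at larger amounts of compound and lower numbers for an effect already at smaller amounts. Compound 1 `CCOC(=O)c1ccc2nc(NC(=O)CNC(=O)c3nn(-c4ccccc4)c(=O)c4ccccc34)sc2c1` gives > 25000 nM, which is a limit of the assay and not a number. Compound 3 `O=C(CNC(=O)c1nn(-c2ccccc2)c(=O)c2ccccc12)Nc1nccs1` likewise gives > 25000 nM, again a limit. Compound 2 `COc1ccc(-n2nc(C(=O)NCC(=O)Nc3nc4ccccc4s3)c3ccccc3c2=O)cc1` gives 25000 nM, the only number shown in this assay. The two other values are limits, and the limit of > 25000 nM in this assay, at which 2 of the 3 values shown sit, marks where those two sit. Going by the values given here, no step between measured compounds that differ in one place is available, so the series so far gives no measured change to lean on.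

Compound 4 `O=C(CNC(=O)c1nn(-c2ccc(F)cc2)c(=O)c2ccccc12)Nc1nc2ccccc2s1` is the next compound to be measured in this assay. It differs from compound 2 by one change, (fluoro in place of methoxy on an aromatic carbon); fluoro in place of methoxy on an aromatic carbon. With compound 2 already sitting next to the limit, the step from compound 2 to compound 4 is expected to be small, no change at the digits printed from compound 2 to compound 4 (within the scatter), and not beyond the scatter in either direction. Compound 4 is accordingly estimated at 25000 nM, in the range 8000 nM to 60000 nM, with a fair chance that this assay reports only a limit.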

Compound 4, half-maximal effective concentration: > 25000 nM
Compound 4 was reported as a limit (the forecaster's own chance of this, stated with the estimate: 55%); the middle value lies on the limit itself.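

In this assay, going by these compounds alone, the first readable step gives a number no lower from compound 2 to compound 4 (the limit leaves the size open), so fluoro in place of methoxy, on an aromatic carbon para to a large group, brings no gain that can be read. This position has now been varied once, and neither group lifts the compound clear of the limit, which is a limit of the assay and not a number. The series remains almost entirely without numbers: the limit of > 25000 nM in this assay, at which 3 of the 4 values shown sit.

How large the step from methoxy to fluoro really is cannot be read, and neither group gives a reason to favour this position over others on the shared core. On these data alone, whether an amine or a carboxylic acid at this position would give a value clearly lower than that of compound 2 stays open.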